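Swapping Nitro for Methoxy in a Cytotoxicity Assay

The source may hold more compounds than are shown below. What is called first, only, known or untested is meant among the compounds shown, and "the series" means these compounds.

Compound 1, `COc1ccc(OC)c(C2=NN(C(C)=O)C(c3ccc(OC)c([N+](=O)[O-])c3)C2)c1`: 58000 nM
Compound 2, `COc1ccc(C2CC(c3cc(OC)c(OC)c(OC)c3)=NN2C(C)=O)cc1[N+](=O)[O-]`: > 100000 nM, which is a limit of the assay rather than a number.

Both compounds were tested in a functional assay on B16 cells (Mus musculus) for cytotoxicity, read by MTT assay, with a stated time of 72 h; on this read-out higher numbers stand for weaker inhibition and lower numbers for stronger inhibition. Compound 1 is the only one of the two with an actual number, 58000 nM, a value that marks it as a weak cytotoxic agent. Compound 2 sits at the limit of > 100000 nM in this assay, at which 1 of the 2 values shown sits. It therefore offers no number to set beside the other compound. Among the measured compounds shown here, no pair of measured compounds differs in a single place, so there is no measured step to lean on.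

Compound 3, `COc1ccc(OC)c(C2=NN(C(C)=O)C(c3ccc(OC)c(OC)c3)C2)c1`, is the unmeasured compound. It differs from compound 1 by methoxy in place of nitro on an aromatic carbon. For the measured compounds named here, with no measured step available, only a rough expectation can be given. Compound 1 already stands at the weak end of what the assay reports, and compound 3 could either stay there or slip into limit territory. The expected step in this assay is a 1.2-fold higher number from compound 1 to compound 3 (0.08 log units; within the scatter), probably no larger than the usual scatter, with a real chance that only a limit is reported. Compound 3 is therefore estimated at 70000 nM, within a range of 20000 nM to 250000 nM.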

Compound 3, half-maximal inhibitory concentration: 62000 nM
For compound 3 the middle estimate is 1.1-fold (0.05 log units) above the measured one, and the stated range covers the measured number.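

In this assay, among the compounds shown here, methoxy in place of nitro on this aromatic carbon, ortho to a methoxy group and meta to a large group, gives a 1.1-fold higher number from compound 1 to compound 3 (0.03 log units; within the scatter) and is the first measured step at this position. Nitro and methoxy differ in their heavy atoms and hydrogen-bond acceptors, and only nitro carries a double bond outside the aromatic ring, yet the two values stay within the scatter of each other. Compound 3 also returns an actual number rather than a limit, so at this position the exchange keeps the compound within the range the assay can report as a number. Nothing given here bears on why the two values lie so close together.

The compounds shown leave open whether any other group on this carbon, such as an amine, a carboxylic acid or a longer chain, would give a step beyond the scatter. They also leave open whether the same exchange of nitro for methoxy would give so small a step on another aromatic carbon of the shared core, since this single pair speaks for one position only.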